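A few compounds are considered here, and "the series" means these few. Any claim that something is new, unique, unknown or untested is made for them only; others in the source may bear on it.

In a functional assay on Hep 3B2 cells (Homo sapiens) for antiproliferative activity, read by sulforhodamine B assay, with a stated time of 48 h; on this read-out higher numbers stand for weaker inhibition of growth and lower numbers for stronger inhibition of growth:
- compound 1 `CC(C)CCc1c(OCCCCCCCC(=O)NO)ccc(CCC(=O)NO)c1O`: 1270 nM
- compound 2 `CC(C)CCc1c(OCCCCC(=O)NO)ccc(CCC(=O)NO)c1O`: 14100 nM
- compound 3 `CC(C)CCc1c(OCCCCCC(=O)NO)ccc(CCC(=O)NO)c1O`: not yet measured

Compound 2 has the higher of the two numbers, at 14100 nM. The change to compound 3 is (hydroxycarbamoyl)methyl in place of hydroxycarbamoyl on a saturated chain carbon, four bonds along the chain from an oxygen on an aromatic ring. For the measured compounds named here, only one measured step bears on it: an 11-fold higher number from compound 1 to compound 2 (1.05 log units; beyond the scatter), with hydroxycarbamoyl replacing 3-(hydroxycarbamoyl)propyl at the same place. The present change reverses only part of that difference, so a modest move to a lower number is expected in this assay. The expected change is a 2.4-fold lower number from compound 2 to compound 3 (0.37 log units; beyond the scatter). For compound 3 the estimated value is 6000 nM, with an expected range of 2300 nM to 14000 nM.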

Compound 3, concentration for 50% growth inhibition: 1980 nM
Beside the measured number, compound 3's estimate is 3.0-fold (0.48 log units) above it; measured number below the stated range.
By their numbers in this assay, from the lowest: compounds 1 and 3 (each within the scatter of the next); then compound 2.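

In this assay, the single added carbon of (hydroxycarbamoyl)methyl in place of hydroxycarbamoyl accounts for most of the gap within this chain series (a 7.1-fold lower number from compound 2 to compound 3 (0.85 log units; beyond the scatter)). Going on to the chain of compound 1 gives no separable change (a 1.6-fold higher number from compound 1 to compound 3 (0.19 log units; within the scatter)), so among these three compounds the response is one sharp step followed by a level stretch. Nothing measured here gives a reason for this step. Still open, from the compounds shown here alone, is whether a chain longer than that of compound 1 holds this level, and whether a carboxylic acid in place of the hydroxycarbamoyl on this chain keeps it.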